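Aryl substitution on the shared core: compound 4

A few compounds are considered here, and "the series" means these few. Any claim that something is new, unique, unknown or untested is made for them only; others in the source may bear on it.

Measured compounds:
compound 1 `COc1cc(/C=C/C(=O)c2cccc(-n3cc(-c4ccc(Cl)cc4)[nH]c3=O)c2)ccc1O` — 3870 nM
compound 2 `COc1cc(/C=C/C(=O)c2cccc(-n3cc(-c4ccccc4)[nH]c3=O)c2)cc(OC)c1OC` — 2170 nM
compound 3 `COc1cc(/C=C/C(=O)c2cccc(-n3cc(-c4ccccc4)[nH]c3=O)c2)ccc1O` — 3360 nM

In a functional assay on MDA-MB-231 cells (Homo sapiens) for inhibition (a higher number here means a weaker inhibitor of growth, a lower number a stronger inhibitor of growth), compound 2 sits at the low end of the three numbers, yet its gaps to compound 3 and compound 1 are within the scatter, so the three compounds are not separated. Compound 4 `COc1ccc(-c2cn(-c3cccc(C(=O)/C=C/c4cc(OC)c(OC)c(OC)c4)c3)c(=O)[nH]2)cc1` differs from compound 2 by methoxy in place of hydrogen on an aromatic carbon. For the measured compounds named here, the one measured step that bears on a change at this position is a 1.2-fold lower number from compound 1 to compound 3 (0.06 log units; within the scatter), which stayed within the scatter. On that basis no step beyond the scatter is expected in this assay, and compound 4 is expected to land near compound 2, the expected step being a 1.0-fold higher number from compound 2 to compound 4 (0.01 log units; within the scatter). Compound 4 is therefore estimated at 2200 nM, with a range of 1000 nM to 4800 nM.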

Compound 4, concentration for 50% growth inhibition: 5480 nM
For compound 4 the middle estimate is 2.5-fold (0.40 log units) below the measured one, outside the stated range (above it).
By their numbers in this assay, from the lowest: compounds 2, 3, 1 and 4 (each within the scatter of the next, the first and the last beyond it).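

In this assay, for the compounds shown here, phenyl to 4-methoxyphenyl gives a 2.5-fold higher number from compound 2 to compound 4 (0.40 log units; beyond the scatter), the first step beyond the scatter at this aromatic carbon, para to a large group. The position therefore responds to substitution, which the earlier exchange of chloro and hydrogen did not show. Nothing on hand accounts for this step. Open, as far as these compounds go, is whether an amine, a carboxylic acid or a longer chain such as butoxy at this carbon would move the number in the same direction. Also open, from the compounds shown here alone, is whether methoxy gives a similar step on the core of compound 3.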